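The compounds below may be only part of what the source reports. "The series", "measured", "known", "first", "only" and "open" are said of these compounds alone.

Among the compounds with values here, compound 3 `Cc1ccc2nc(Cl)c(/C=N/n3cc(-c4ccc(Br)cc4)nc3N)cc2c1` gives the highest of the three numbers so far in a functional assay on DLD-1 cells (Homo sapiens) for cytotoxicity, read by MTT assay, with a stated time of 48 h (on this read-out higher numbers stand for weaker inhibition and lower numbers for stronger inhibition), at 39300 nM. Compound 2 `Cc1ccc2nc(Cl)c(/C=N/n3cc(-c4ccc(Cl)cc4)nc3N)cc2c1` gives 38900 nM in this assay, and the step of a 1.0-fold higher number from compound 2 to compound 3 (0.00 log units; within the scatter) lies within the scatter. Compound 1 `Cc1ccc2nc(Cl)c(/C=N/n3cc(-c4ccccc4)nc3N)cc2c1` gives 8790 nM, so the steps of a 4.5-fold higher number from compound 1 to compound 3 (0.65 log units; beyond the scatter) and a 4.4-fold higher number from compound 1 to compound 2 (0.65 log units; beyond the scatter) both lie beyond it. Compound 4 `Cc1ccc2nc(Cl)c(/C=N/n3cc(-c4cccc5ccccc45)nc3N)cc2c1` differs from compound 3 by naphthalen-1-yl in place of 4-bromophenyl on an aromatic carbon. Within the data shown here, no measured step swaps a halogenated phenyl for a fused ring; the steps that bear on it show only that the halogen-free compound 1 sits lower, as in a 4.5-fold higher number from compound 1 to compound 3 (0.65 log units; beyond the scatter), while the exchange of one halogen for another, a 1.0-fold higher number from compound 2 to compound 3 (0.00 log units; within the scatter), changes nothing beyond the scatter. For compound 4 a step of a 2.0-fold lower number from compound 3 to compound 4 (0.29 log units; within the scatter) in this assay is therefore expected, towards a lower number, with an estimate of 20000 nM and a range from 6000 nM to 60000 nM.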

Compound 4, half-maximal inhibitory concentration: 8300 nM
Beside the measured number, compound 4's estimate is 2.4-fold (0.38 log units) above it; low and high end bracket the measured number.
By their numbers in this assay, from the lowest: compounds 4 and 1 (each within the scatter of the next); then compounds 2 and 3 (each within the scatter of the next).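

On this aromatic carbon, this assay now shows a fused ring in place of a halogenated phenyl, with a 4.7-fold lower number from compound 3 to compound 4 (0.68 log units; beyond the scatter) and a 4.7-fold lower number from compound 2 to compound 4 (0.67 log units; beyond the scatter) as the steps, so the two halogenated compounds stand apart from naphthalen-1-yl as well as from phenyl. The step of a 1.1-fold lower number from compound 1 to compound 4 (0.02 log units; within the scatter) stays within the scatter, and phenyl and naphthalen-1-yl cannot be told apart here. Nothing measured here accounts for this result. Going by these compounds, whether a methoxy group, an amine or a carboxylic acid on the phenyl would fall with the halogens or with the plain phenyl stays open, as does the effect of naphthalen-2-yl.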